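This account rests on a few compounds, and the source may have more. Where it says the series, first, only, none or still open, it means among the compounds named here.

Series notes. Among the compounds with values here, compound 1 `Cc1nc(-c2ccccc2)c(C(=O)N2CCN(c3cccc(Cl)c3)CC2)o1` is the one member of this set with a number in a functional assay on HL-60 cells (Homo sapiens) for inhibition, read by MTT assay, with a stated time of 72 h; on this read-out higher numbers stand for weaker inhibition and lower numbers for stronger inhibition: compound 1 gives 39.2 nM. Compound 2 `Cc1nc(-c2ccccc2)c(C(=O)N2CCN(c3ccc(C(F)(F)F)cc3)CC2)o1` carries 4-(trifluoromethyl)phenyl in place of 3-chlorophenyl on the amine nitrogen in the ring. In this assay compound 2 returns only a limit, > 1000 nM. The step of an at least 25-fold higher number from compound 1 to compound 2 (1.40 log units; beyond the scatter) rests on the limit of > 1000 nM in this assay, at which 1 of the 2 values shown sits, and marks that exchange on the amine aryl as costly.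

Compound 3 `COc1cccc(-c2nc(C)oc2C(=O)N2CCN(c3cccc(Cl)c3)CC2)c1` leaves the amide side of compound 1 untouched and alters the phenyl on the shared core. The counted difference is methoxy in place of hydrogen on an aromatic carbon: methoxy enters on an aromatic carbon of a six-membered aromatic ring of carbon only, meta to a large group, so that phenyl reads 3-methoxyphenyl. Within the data shown here, no measured step touches this ring; the only step in hand sits on the aryl of the amine nitrogen in the ring and gives no guide to a methoxy here. With nothing bearing on the change, the expected step in this assay is a 1.3-fold higher number from compound 1 to compound 3 (0.11 log units; within the scatter), within the scatter. Compound 3 is estimated at 50 nM, with a range from 15 nM to 200 nM.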

Compound 3, half-maximal inhibitory concentration: "not active" (no number reported)
The entry for compound 3 holds no number; no gap can be computed for the estimate.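

Within the data shown here, compound 3 is entered only as "not active", without a number, so no step from compound 1 to compound 3 can be read in this assay. Compound 2 also gives no number, only a limit: the limit of > 1000 nM in this assay, at which 1 of the 3 values shown sits. The compounds shown leave open how much, if at all, 3-methoxyphenyl in place of phenyl changes the value of compound 1.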